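A Nitro Group Added to the Phenyl Ring

The source may report more compounds than this note shows. Statements on the series, on what has been measured and on what is new or still open speak of the compounds shown alone.

Among the compounds with values here, compound 1 `O=C1C(O)=C(C(c2ccccc2)c2c(-c3ccccc3)[nH]c3ccccc23)C(=O)c2ccccc21` is one of two compounds measured in a toxicity assay (Homo sapiens) for cytotoxicity, read by MTT assay, with a stated time of 48 h; a lower number here means a stronger inhibitor, a higher number a weaker inhibitor. In this assay compound 1 gives 26400 nM, the highest of the two numbers. The other one, compound 2 `Cc1[nH]c2ccccc2c1C(C1=C(O)C(=O)c2ccccc2C1=O)c1ccc([N+](=O)[O-])cc1`, gives 15100 nM in this assay; the gap between these two values lies within the usual scatter, so the two cannot be told apart. Within the data shown here, compound 2 differs from compound 1 in more than one place, so its value sets no single step.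

Compound 3 `O=C1C(O)=C(C(c2cccc([N+](=O)[O-])c2)c2c(-c3ccccc3)[nH]c3ccccc23)C(=O)c2ccccc21` has not yet been measured. It differs from compound 1 by one change: nitro in place of hydrogen on an aromatic carbon. Among the measured compounds shown here, no step between measured compounds shows what such a change does here. With nothing to guide it, the expected change is small, a 1.7-fold lower number from compound 1 to compound 3 (0.22 log units; within the scatter), tending if anything toward a lower number. The estimate for compound 3 in this assay is 16000 nM, with a range from 5000 nM to 50000 nM.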

Compound 3, half-maximal inhibitory concentration: 13400 nM
The estimate for compound 3 lay 1.2-fold (0.08 log units) above the measured number; measured number inside the range.
By their numbers in this assay, from the lowest: compounds 3, 2 and 1 (each within the scatter of the next).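

Adding the nitro group gives the first step that can be read at this position of the core of compound 1: in this assay, going from phenyl to 3-nitrophenyl amounts to a 2.0-fold lower number from compound 1 to compound 3 (0.29 log units; within the scatter), and the core stays the same. A nitro group, with its three heavy atoms, can therefore sit on this aromatic carbon, meta to a large group, without moving the number beyond the ordinary spread of repeated measurements. No separate measurement bears on what lies behind this result.

On these data alone, on the core of compound 1, the nitro group appears at this one place only, so what it would do elsewhere on the ring remains open. Also open, as far as these compounds go, is whether another group here, such as an amine or a carboxylic acid, would move the number beyond the scatter.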